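Swapping the amine on the diazeniumdiolate end

The source may hold more compounds than are shown below. What is called first, only, known or untested is meant among the compounds shown, and "the series" means these compounds.

Compound 1: `CN(C)/[N+]([O-])=N/Oc1cc(O/N=[N+](\[O-])N2CCCCC2)c([N+](=O)[O-])cc1[N+](=O)[O-]` — 1700 nM
Compound 2: `CN(C)/[N+]([O-])=N/Oc1cc(O/N=[N+](\[O-])N2CCCC2CO)c([N+](=O)[O-])cc1[N+](=O)[O-]` — 1000 nM
Compound 3: `CCN(CC)/[N+]([O-])=N/Oc1cc(O/N=[N+](\[O-])N(C)C)c([N+](=O)[O-])cc1[N+](=O)[O-]` — not yet measured

Of the compounds shown here, two have been tested so far in a functional assay on HL-60 cells (Homo sapiens) for antiproliferative activity, read by MTT assay, with a stated time of 72 h; on this read-out lower numbers stand for stronger inhibition and higher numbers for weaker inhibition. Compound 1 gives 1700 nM and compound 2 gives 1000 nM. Going by the values given here, compound 2 therefore has the lower of the two numbers, but the only step between them, a 1.7-fold lower number from compound 1 to compound 2 (0.23 log units; within the scatter), lies within the scatter of this assay, so the two cannot be told apart on potency.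

Compound 3 arises from compound 2 by a change at the same place: diethylamino in place of 2-(hydroxymethyl)pyrrolidin-1-yl on a double-bonded nitrogen. Among the compounds with values here, the single measured step touches this very position, and it showed that exchanging one amine for another there did not move the number beyond the scatter. Within the data shown here, no measured step covers an amine without a ring or without a hydroxymethyl, so the expectation rests on that one step alone. A step of about a 1.3-fold higher number from compound 2 to compound 3 (0.11 log units; within the scatter) is expected, which is no real change in this assay. Compound 3 is therefore estimated at 1300 nM, with a likely range from 500 nM to 4000 nM.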

Compound 3, half-maximal inhibitory concentration: 1000 nM
Estimate against measurement, compound 3: 1.3-fold (0.11 log units) above; measured number inside the range.
By their numbers in this assay, from the lowest: compounds 2, 3 and 1 (each within the scatter of the next).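

In this assay, the amine on the double-bonded nitrogen can now be seen without any ring: diethylamino in place of 2-(hydroxymethyl)pyrrolidin-1-yl gives no change at the digits printed from compound 2 to compound 3 (within the scatter) even though the entering group has no ring and 0 hydrogen-bond donors, while the leaving group has a five-membered non-aromatic ring and 1 hydrogen-bond donor. Set against the piperidin-1-yl group, diethylamino gives a 1.7-fold lower number from compound 1 to compound 3 (0.23 log units; within the scatter) and so also stays within the scatter, which means that the open-chain amine, the plain ring and the ring with a hydroxymethyl cannot be told apart at this position. Nothing beyond these numbers is available to explain why the three amines read alike.

From the compounds shown here alone, it remains open whether any group at this position can move the number beyond the scatter, for example a much longer chain such as dioctylamino, or an amine carrying a carboxylic acid. A morpholin-4-yl ring, with a second hetero atom in place of a ring carbon, would test the ring itself in a further way.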